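Chloro for methyl on a charged-chain aryl ring

A few compounds are considered here, and "the series" means these few. Any claim that something is new, unique, unknown or untested is made for them only; others in the source may bear on it.

Of the compounds shown here, two have been measured in an assay on LX2 cells for inhibition of COL1A1 promoter (Homo sapiens), read by a luciferase reporter, with a stated time of 24 h, tested at 50 uM; a lower number here means a weaker effect, a higher number a stronger effect of the compound at the concentration tested. Compound 1 `CN(C)c1ccc2c(=O)c(C(=O)Nc3cc(F)cc(F)c3)cn(-c3ccc(Cl)c(OCCCCCCC[N+]4(C)CCCCC4)c3)c2n1` gives 90.5% there. Compound 2 `Cc1ccc(-n2cc(C(=O)Nc3cc(F)cc(F)c3)c(=O)c3ccc(N(C)C)nc32)cc1OCCCCCCC[n+]1ccccc1` gives 22.2%, the lower of the two numbers and well beyond the scatter from compound 1. Compound 3 `CN(C)c1ccc2c(=O)c(C(=O)Nc3cc(F)cc(F)c3)cn(-c3ccc(Cl)c(OCCCCCCC[n+]4ccccc4)c3)c2n1` is unmeasured; it differs from compound 2 by chloro in place of methyl on an aromatic carbon, on an aromatic carbon ortho to a large group and para to a large group. Within the data shown here, no measured pair shows this exact change, so the step is uncertain, but a rise beyond the scatter is expected, with compound 3 estimated at 60% (range 25% to 90%), a step of a number 37.8 percentage points higher from compound 2 to compound 3 (beyond the scatter) in this assay.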

Compound 3, a percentage reported as inhibition, at one concentration (the size of the read-out at that concentration, not a potency): 77.9%
The estimate for compound 3 lay 17.9 percentage points below the measured number, within the range that was stated.
By their numbers in this assay, from the lowest: compound 2; then compound 3; then compound 1.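

In this assay, chloro in place of methyl on this aromatic carbon, ortho to a large group and para to a large group, gives a number 55.7 percentage points higher from compound 2 to compound 3 (beyond the scatter), so a swap of a single heavy atom here carries a large effect. With chloro held fixed, the six-membered aromatic ring at the chain end in place of the six-membered non-aromatic ring gives a number 12.6 percentage points lower from compound 1 to compound 3 (beyond the scatter). Nothing measured here explains why chloro outperforms methyl at this carbon. As far as these compounds go, whether fluoro or methoxy at this carbon, or a shorter chain, would match chloro remains open.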